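A piperidin-1-yl exchange without a measured starting point

The compounds below may be only part of what the source reports. "The series", "measured", "known", "first", "only" and "open" are said of these compounds alone.

In a physicochemical assay for lipophilicity, using the shake flask method, at pH 7.4 (a higher number here means a more lipophilic compound, a lower number a more polar compound), the record is thin. Compound 1 `c1ccc(CCCC2CCCCC2)cc1` gives "nd" (no result reported) as its entry and compound 2 `c1ccc(COCCCCC2CCCCC2)cc1` gives "nd" (no result reported) as its entry, so compound 2 stands without a single number, and one further compound shares that gap. Within the data shown here, compound 3 `c1ccc(COCCCON2CCCCC2)cc1` gives 3 and holds the only number. Compound 4 `c1ccc(COCCCCN2CCCCC2)cc1` still awaits measurement. The change leading to it is piperidin-1-yl in place of cyclohexyl on a saturated chain carbon, four bonds along the chain from an oxygen on a saturated carbon and amounts to piperidin-1-yl in place of cyclohexyl on a saturated chain carbon, four bonds along the chain from an oxygen on a saturated carbon. Among the measured compounds shown here, no measured step in this assay shows what this exchange does, so the expectation is a judgement: a clear downward step from compound 2, beyond the scatter, of a size that no number here can anchor. Compound 3 at 3 is the sole reference for the level, and compound 4 is expected to sit lower than that. Compound 4 is estimated at 1.8 with an expected range from 1 to 2.6 in this measurement.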

Compound 4, distribution coefficient: 0.9
For compound 4 the middle estimate is 0.90 log units above the measured one; measured number outside the range, below it.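

Among these compounds, compound 2 holds no single number in this assay, so no step to compound 4 can be read. What piperidin-1-yl in place of cyclohexyl does to this measurement stays open in the compounds shown. Nothing available here bears on the result of compound 4.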